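A few compounds are considered here, and "the series" means these few. Any claim that something is new, unique, unknown or untested is made for them only; others in the source may bear on it.

Measured compounds in a functional assay on the whole organism (strain albino) with Mus musculus as the target, in the maximal electroshock model, with a stated time of 4 h; a higher number here means that more compound is needed for the effect, a lower number that less compound is needed:
- compound 1 `Cc1ccccc1Nc1nnc(Nc2nc(-c3ccc(Cl)cc3)cs2)s1` gives 300 mg/kg
- compound 2 `COc1ccccc1Nc1nnc(Nc2nc(-c3ccc(Cl)cc3)cs2)s1` gives 300 mg/kg
- compound 3 `COc1ccc(Nc2nnc(Nc3nc(-c4ccc(Cl)cc4)cs3)s2)cc1` gives 300 mg/kg

Compound 3 stands level with compounds 1 and 2 on these numbers. The three measured steps, no change at the digits printed from compound 1 to compound 2 (within the scatter), no change at the digits printed from compound 1 to compound 3 (within the scatter) and no change at the digits printed from compound 2 to compound 3 (within the scatter), all lie within the scatter, so every change made so far on the aryl group of the amine has left the minimum effective dose where it was.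

Compound 4 `Clc1ccc(-c2csc(Nc3nnc(Nc4ccccc4)s3)n2)cc1` differs from compound 3 by hydrogen in place of methoxy on an aromatic carbon. Within the data shown here, none of the measured steps removes a substituent outright; the nearest are the moves of the methoxy between positions and the swap of methoxy for methyl, which are the flat steps just given. On that basis the step from compound 3 to compound 4 in this assay is expected to be no change at the digits printed from compound 3 to compound 4 (within the scatter), that is, nothing beyond the scatter. Compound 4 is therefore estimated at 300 mg/kg, with a range from 100 mg/kg to 600 mg/kg.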

Compound 4, minimum effective dose: 300 mg/kg
Beside the measured number, compound 4's estimate shows no gap at the digits printed, within the range that was stated.
By their numbers in this assay, from the lowest: compounds 1, 2, 3 and 4 (each within the scatter of the next).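

In this assay the loss of the substituent is now read directly: hydrogen in place of methoxy gives no change at the digits printed from compound 3 to compound 4 (within the scatter) and also no change at the digits printed from compound 2 to compound 4 (within the scatter) while hydrogen in place of methyl gives no change at the digits printed from compound 1 to compound 4 (within the scatter) as the third new step. The plain phenyl therefore sits level with the methyl and methoxy compounds, so among these four compounds the minimum effective dose does not depend on having either substituent on this ring. No supporting data bear on why these steps are flat.

From the compounds shown here alone, whether a carboxylic acid or a dimethylamino group on this phenyl would shift the dose remains open. So does the effect of replacing the chlorine in the shared core with, for example, a nitrile.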